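The source may report more compounds than this note shows. Statements on the series, on what has been measured and on what is new or still open speak of the compounds shown alone.

Measured compounds:
compound 1, `O=C(Nc1cc(-c2ccccc2)nn1-c1ccccc1)c1ccc(OC(F)(F)F)cc1`, 265 nM in an assay on HEK293 cells for displacement of a labelled ligand from metabotropic glutamate receptor 5 (Rattus norvegicus); on this read-out higher numbers stand for weaker inhibition and lower numbers for stronger inhibition
compound 2, `NC(=O)c1ccc(C(=O)Nc2cc(-c3ccccc3)nn2-c2ccccc2)cc1`, > 10000 nM in this assay

Compound 2 stands at the lower edge of what has been measured: its value in this assay is a limit of the assay, not a number, as stated in the limit of > 10000 nM in this assay, at which 1 of the 2 values shown sits. The change to compound 3, `O=C(CC1CCCC1)Nc1cc(-c2ccccc2)nn1-c1ccccc1`, is cyclopentylmethyl in place of 4-carbamoylphenyl on a carbonyl carbon. Among the compounds with values here, the one measured step, an at least 37-fold higher number from compound 1 to compound 2 (1.57 log units; beyond the scatter), bears on it only indirectly, since it shows that the carbamoyl-bearing aryl group of compound 2 is the weaker of the two measured variants, while no measured compound carries a non-aromatic group on that carbonyl carbon. Removing the carbamoyl group is therefore expected to move the value back downward from the limit, though how far is uncertain. Compound 3 is expected to give 2000 nM, within 300 nM to 15000 nM. This estimate corresponds to a step of an at least 5.0-fold lower number from compound 2 to compound 3 (0.69 log units; beyond the scatter).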

Compound 3, inhibition constant: > 10000 nM
Compound 3: no number, only a limit (the forecaster's own chance of this, stated with the estimate: 25%); at least 5.0-fold (0.69 log units) between middle value and limit.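

In this assay compound 3 gives > 10000 nM, a limit of the assay and not a number. Compound 2 also stands at a limit, and the step between compound 2 and compound 3 cannot be read. The compounds shown leave open whether cyclopentylmethyl or 4-carbamoylphenyl on the carbonyl carbon gives the weaker inhibition.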